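This account rests on a few compounds, and the source may have more. Where it says the series, first, only, none or still open, it means among the compounds named here.

Measured so far in a functional assay on isolated protein for agonist activity at Glucose-dependent insulinotropic receptor (Homo sapiens), read by HTRF and cAMP accumulation; on this read-out higher numbers stand for an effect only at larger amounts of compound and lower numbers for an effect already at smaller amounts:
compound 1, `CC(C)OC(=O)N1CCC(O[C@H]2CC[C@H](Oc3cnc(S(C)(=O)=O)cn3)CC2)CC1`: 13.7 nM
compound 2, `CC1(OC(=O)N2CCC(O[C@H]3CC[C@H](Oc4cnc(S(C)(=O)=O)cn4)CC3)CC2)CC1`: 25.9 nM

Two compounds share one core and differ only in the group on an oxygen next to a carbonyl group. Among the two numbers measured, compound 2 cannot be set apart from compound 1: the step of a 1.9-fold higher number from compound 1 to compound 2 (0.28 log units; within the scatter) lies within the scatter, so in this assay the two compounds behave alike.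

Compound 3, `C[C@H](CF)OC(=O)N1CCC(O[C@H]2CC[C@H](Oc3cnc(S(C)(=O)=O)cn3)CC2)CC1`, keeps everything of compound 2 except that group: 1-(fluoromethyl)ethyl in place of 1-methylcyclopropyl on an oxygen next to a carbonyl group. For the measured compounds named here, the only measured step that bears on this position is the one from compound 1 to compound 2, where a change of the same kind, a different small group on the same oxygen, gave a 1.9-fold higher number from compound 1 to compound 2 (0.28 log units; within the scatter) and thus no shift beyond the scatter. Going by the values given here, with only that step to go by, the change to compound 3 is expected to give a step of about a 1.3-fold lower number from compound 2 to compound 3 (0.11 log units; within the scatter) in this assay, that is, none beyond the scatter in either direction. Compound 3 is therefore estimated at 20 nM in this assay, with a likely range from 8 nM to 50 nM.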

Compound 3, half-maximal effective concentration: 36.8 nM
Compound 3: middle estimate off by 1.8-fold (0.26 log units), on the low side; measured number inside the range.
By their numbers in this assay, from the lowest: compounds 1, 2 and 3 (each within the scatter of the next, the first and the last beyond it).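

In this assay, putting the open-chain 1-(fluoromethyl)ethyl in place of 1-methylcyclopropyl gives a 1.4-fold higher number from compound 2 to compound 3 (0.15 log units; within the scatter), so on this oxygen the three-membered ring can go without a shift that stands out from the scatter. For the compounds shown here, the more telling comparison is with compound 1, which differs from compound 3 only by fluoro in place of hydrogen on a saturated chain carbon: that single change gives a 2.7-fold higher number from compound 1 to compound 3 (0.43 log units; beyond the scatter), the first step at this position to pass beyond the scatter, though only a modest one. No further measurement accompanies these compounds that would explain this step.

The compounds shown leave open how the 1-(fluoromethyl)ethyl group would read with the opposite arrangement at its stereocentre, since only one form appears here. They also leave open whether the step seen with a single fluorine would carry over to a difluoromethyl or trifluoromethyl group at the same place, or to a hydroxyl group on that carbon instead.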